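The source may report more compounds than this note shows. Statements on the series, on what has been measured and on what is new or still open speak of the compounds shown alone.

Compound 1 `Cc1ccc(S(=O)(=O)N2CC=C(Cl)CC2)cc1` in a functional assay on WiDr cells (Homo sapiens) for antiproliferative activity, read by sulforhodamine B assay, with a stated time of 48 h (on this read-out lower numbers stand for stronger inhibition of growth and higher numbers for weaker inhibition of growth), gives > 100000 nM.
Compound 2 `Cc1ccc(S(=O)(=O)N2CCC(Cl)=CC2C2CCCCC2)cc1` in this assay gives 24000 nM.
Compound 3 `Cc1ccc(S(=O)(=O)N2CC=C(Br)CC2)cc1` in this assay gives > 100000 nM.

The value for compound 3 is a limit of the measurement, not a number. The same holds for compound 1, and the limit of > 100000 nM in this assay, at which 2 of the 3 values shown sit, marks this shared boundary. Only compound 2 gives a readable number. The step from compound 1 to compound 3 is a step that the two limits leave unreadable from compound 1 to compound 3, so the bromo and chloro versions of the shared core cannot be told apart here.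

Compound 4 `Cc1ccc(S(=O)(=O)N2CCC(Br)=CC2c2ccccc2)cc1` has not been measured in this assay. It differs from compound 3 by phenyl in place of hydrogen on a saturated ring carbon. The closest measured step is an at least 4.1-fold lower number from compound 1 to compound 2 (0.61 log units; beyond the scatter), where a cyclohexyl enters the same place on the chloro core. A phenyl is a different ring, but by that step a move off the limit to a measurable number is expected for compound 4, as an at least 4.0-fold lower number from compound 3 to compound 4 (0.60 log units; beyond the scatter). Compound 4 is therefore estimated at 25000 nM, in a range from 8000 nM to 80000 nM.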

Compound 4, concentration for 50% growth inhibition: 29000 nM
Compound 4: middle estimate off by 1.2-fold (0.06 log units), on the low side, within the range that was stated.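

In this assay the new result is an at least 3.4-fold lower number from compound 3 to compound 4 (0.53 log units; beyond the scatter). Until now, a ring on this saturated ring carbon, next to the ring nitrogen, had been seen only as cyclohexyl on the chloro core; phenyl on the bromo core also gives a readable number, so among these compounds the move off the limit is not confined to one halogen or to one kind of ring. The two compounds without a ring at this place stay at the shared boundary: the limit of > 100000 nM in this assay, at which 2 of the 4 values shown sit.

Compound 2 and compound 4 differ in two places, so these values cannot rank phenyl against cyclohexyl. From the compounds shown here alone, it also remains open whether a smaller group such as methyl at this carbon, or a phenyl ring carrying an amine or a carboxylic acid, would give a readable number.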